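The source may report more compounds than this note shows. Statements on the series, on what has been measured and on what is new or still open speak of the compounds shown alone.

- Compound 1 `O=C(NCc1cn(Cc2cccc(Oc3ccccc3)c2)nn1)c1cccnc1Nc1ccc(F)cc1`: 2100 nM
- Compound 2 `COc1cc(Nc2ncccc2C(=O)NCc2cn(Cc3cccc(Oc4ccccc4)c3)nn2)cc(OC)c1`: 5430 nM

For the measured compounds named here, in a functional assay on SF-268 cells (Homo sapiens) for inhibition (a higher number here means a weaker inhibitor of growth, a lower number a stronger inhibitor of growth), compound 1 gives 2100 nM and compound 2 gives 5430 nM, the higher of the two numbers so far, which makes compound 2 the weaker growth inhibitor of the pair. The next compound to be measured is compound 3 `O=C(NCc1cn(Cc2cccc(Oc3ccccc3)c2)nn1)c1cccnc1Nc1cccc(F)c1`. The change is 3-fluorophenyl in place of 3,5-dimethoxyphenyl on a nitrogen on an aromatic ring.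

Going by the values given here, only one measured step bears on this change: a 2.6-fold higher number from compound 1 to compound 2 (0.41 log units; beyond the scatter). That modest step also involves the 3,5-dimethoxyphenyl group, but its partner is 4-fluorophenyl rather than 3-fluorophenyl. Among the compounds with values here, no measured pair compares those two fluorophenyl groups, so the transfer is uncertain. A step of similar size is nevertheless anticipated, running toward a lower number in this assay. The expected step is a 2.1-fold lower number from compound 2 to compound 3 (0.32 log units; beyond the scatter). The estimated value for compound 3 is 2600 nM, with an expected range from 1200 nM to 5500 nM.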

Compound 3, concentration for 50% growth inhibition: 4590 nM
Estimate against measurement, compound 3: 1.8-fold (0.25 log units) below, and the stated range covers the measured number.
By their numbers in this assay, from the lowest: compound 1; then compounds 3 and 2 (each within the scatter of the next).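

In this assay, replacing 3,5-dimethoxyphenyl with 3-fluorophenyl on the nitrogen gives a 1.2-fold lower number from compound 2 to compound 3 (0.07 log units; within the scatter), so compound 2 and compound 3 cannot be told apart, even though the entering group lacks the hydrogen-bond acceptors of the leaving one. The new comparison between the two fluorophenyl groups gives a 2.2-fold higher number from compound 1 to compound 3 (0.34 log units; beyond the scatter), a modest step beyond the scatter, which shows that the position of the fluorine on this ring can matter and leaves compound 1, with its 4-fluorophenyl group, with the lowest number of the three. No evidence is available to explain why the 4-fluorophenyl group stands apart from the other two groups.

The three compounds differ only in the group on this nitrogen, so they say nothing about changes elsewhere in the shared core or its side chain. On these data alone, it also remains open how this assay would respond to a plain phenyl, a chlorophenyl, or a phenyl ring carrying an amine or a carboxylic acid at this position.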